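The source may hold more compounds than are shown below. What is called first, only, known or untested is meant among the compounds shown, and "the series" means these compounds.

Series notes. In a functional assay on the whole organism for inhibition, with Brassica rapa subsp. chinensis as the target, with a stated time of 3 days, tested at 100 ppm (a higher number here means more inhibition of growth at the concentration tested, a lower number less inhibition of growth), compound 1 `CC(C)NC(=O)/C=C/c1ccccc1` gives 39%. Among the compounds with values here, compound 2 `CC(C)CNC(=O)/C=C/c1ccccc1` gives 34% in this assay, which places it at the same level as compound 1 within the usual scatter; the only measured step, a number 5 percentage points lower from compound 1 to compound 2 (within the scatter), carries nothing beyond that scatter. Compound 3 `CCCOC(=O)/C=C/c1ccccc1` has not yet been measured in this assay. Its change from compound 2 is propoxy in place of isobutylamino on a carbonyl carbon. Within the data shown here, no measured step bears on this kind of change: the step from compound 1 to compound 2 concerns only the group on the amide-type nitrogen and was within the scatter, so it gives no direction for putting propoxy in place of isobutylamino on the carbonyl carbon. No step beyond the scatter is therefore expected, and the expected step for compound 3 is a number 1 percentage points higher from compound 2 to compound 3 (within the scatter). Compound 3 is estimated at 35% in this assay, with a range from 10% to 65%.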

Compound 3, percent growth inhibition at one concentration: 31%
For compound 3 the middle estimate is 4 percentage points above the measured one; the measured number falls inside the stated range.
By their numbers in this assay, from the lowest: compounds 3, 2 and 1 (each within the scatter of the next).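

Propoxy in place of isobutylamino on the carbonyl carbon gives a number 3 percentage points lower from compound 2 to compound 3 (within the scatter) and propoxy in place of isopropylamino gives a number 8 percentage points lower from compound 1 to compound 3 (within the scatter) so in this assay the atom attached to the carbonyl carbon has now been changed, and not only the group on the amide-type nitrogen. Propoxy has no hydrogen-bond donor where both amino groups carry the amide hydrogen, yet neither step lies beyond the scatter, so this exchange shows that an ester of this kind holds the same level as the two amides in this read-out. Nothing measured beyond growth inhibition bears on why these numbers stay together.

Still open, going by these compounds, is whether a carboxylic acid or a longer chain on the carbonyl carbon would give a step beyond the scatter. Also open, on these data alone, is whether a primary amide would do so.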